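Indane for Indole: Expected Clearance in Rat

The compounds below may be only part of what the source reports. "The series", "measured", "known", "first", "only" and "open" are said of these compounds alone.

Measured so far:
compound 1 `CCC(=O)Nc1cc(Nc2ncc(Br)c(Nc3ccc4cc[nH]c4c3)n2)c(OC)cc1N1CCN(C)CC1` gives 48.6 mL/min/kg
compound 2 `C=CC(=O)Nc1cc(Nc2ncc(Br)c(Nc3ccc4ccn(C)c4c3)n2)c(OC)cc1N1CCN(C)CC1` gives 32.6 mL/min/kg

In an ADME assay on the whole organism (Rattus norvegicus, strain Sprague-Dawley) for pharmacokinetics, read by LC-MS, with a stated time of 24 h, at a dose of 1 mg/kg by the intravenous route (on this read-out lower numbers stand for slow clearance and higher numbers for fast clearance), compound 1 gives 48.6 mL/min/kg, while compound 2 gives 32.6 mL/min/kg. The two numbers lie within the scatter of each other, so compound 2 is not set apart from compound 1.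

Compound 3 `C=CC(=O)Nc1cc(Nc2ncc(Br)c(Nc3ccc4c(c3)CCC4)n2)c(OC)cc1N1CCN(C)CC1` differs from compound 2 by 2,3-dihydro-1H-inden-5-yl in place of 1-methyl-1H-indol-6-yl on a nitrogen on an aromatic ring. For the measured compounds named here, no pair of measured compounds shows this change, so nothing here points in either direction. In this assay compound 3 is expected to give 35 mL/min/kg, with a range from 18 mL/min/kg to 70 mL/min/kg. The expected step of a 1.1-fold higher number from compound 2 to compound 3 (0.03 log units; within the scatter) stays within the scatter.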

Compound 3, clearance: 15.9 mL/min/kg
The estimate for compound 3 lay 2.2-fold (0.34 log units) above the measured number; the measured number lies below the stated range.
By their numbers in this assay, from the lowest: compound 3; then compounds 2 and 1 (each within the scatter of the next).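

In this assay, the group on this nitrogen makes a difference: 2,3-dihydro-1H-inden-5-yl in place of 1-methyl-1H-indol-6-yl gives a 2.1-fold lower number from compound 2 to compound 3 (0.31 log units; beyond the scatter), a modest step that the earlier pair, which differs in more than one place, could not show. The change replaces a five-membered aromatic ring with one hetero atom by a non-aromatic ring of carbon only. No measurement here explains the lower number. Still open, as far as these compounds go, is whether a plain phenyl group on this nitrogen would give a similar number, and which part of the change carries the step.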